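A few compounds are considered here, and "the series" means these few. Any claim that something is new, unique, unknown or untested is made for them only; others in the source may bear on it.

Measured compounds:
compound 1 `CCOc1cccc(-c2ccc(CN(C(=O)C3CCCCC3)c3cccc(/C=C/C(=O)OC)c3)cc2)c1` with 147 nM
compound 2 `COC(=O)/C=C/c1cccc(N(Cc2ccc(-c3ccc(C(C)(C)C)cc3)cc2)C(=O)C2CCCCC2)c1` with 132 nM
compound 3 `COC(=O)/C=C/c1cccc(N(Cc2cccc(Br)c2)C(=O)C2CCCCC2)c1` with > 1000 nM

In an assay on isolated protein with Bile acid receptor (Homo sapiens) as the target (a lower number here means that less compound is needed, a higher number that more compound is needed for the effect), compound 1 gives 147 nM and compound 2 gives 132 nM. For compound 3 this assay reports only a limit, > 1000 nM; the value the limit of > 1000 nM in this assay, at which 1 of the 3 values shown sits, is not a number. Among the compounds with values here, compound 3 therefore stands apart from compounds 1 and 2 without a known distance, and no single-point step links it to either of them.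

Compound 4 `COC(=O)/C=C/c1cccc(N(Cc2ccc(Br)cc2)C(=O)C2CCCCC2)c1` differs from compound 3 by 4-bromophenyl in place of 3-bromophenyl on a saturated chain carbon bound to an amide-type nitrogen. Within the data shown here, the one measured step, a 1.1-fold lower number from compound 1 to compound 2 (0.05 log units; within the scatter), concerns a different part of the molecule and does not bear on a move of bromine around the benzyl ring. What remains is that compounds 1 and 2, which differ from compound 3 in more than one place, give numbers in this assay while compound 3 gives only a limit; the data do not show how much of that gap belongs to the bromine position alone.

Compound 4 is therefore expected to sit near the limit, with the step of an at least 1.4-fold lower number from compound 3 to compound 4 (0.15 log units; that floor lies within the scatter) estimated only loosely. The estimate for compound 4 in this assay is 700 nM, within 150 nM to 3000 nM.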

Compound 4, half-maximal effective concentration: > 1000 nM
Compound 4: only a limit was reported (the forecaster's own chance of this, stated with the estimate: 40%); at least 1.4-fold (0.15 log units) between middle value and limit.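

In this assay compound 4 reports only a limit, > 1000 nM, and this is a limit of the assay rather than a number. Going from 3-bromophenyl to 4-bromophenyl therefore brings no readable gain, and the step between the two bromo compounds cannot be read, as both stay at the same ceiling: the limit of > 1000 nM in this assay, at which 2 of the 4 values shown sit.

The first single-place links from a bromo compound to measured numbers now exist: bromo in place of 4-(tert-butyl)phenyl on an aromatic carbon gives an at least 7.5-fold higher number from compound 2 to compound 4 (0.87 log units; beyond the scatter), and bromo in place of 3-ethoxyphenyl at that carbon gives an at least 6.8-fold higher number from compound 1 to compound 4 (0.83 log units; beyond the scatter). At this carbon, both aryl groups, which lie within the scatter of each other, give numbers in this assay, whereas bromo in either benzyl arrangement does not.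

From the compounds shown here alone, how far the two bromo compounds lie beyond the limit stays unknown, so any effect of the bromine position remains hidden. Also open, going by these compounds, is whether plain phenyl at that aromatic carbon is enough to return a number, and whether a carboxylic acid in place of the methyl ester keeps the values of the aryl compounds.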